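From 3-aminophenyl to 4-chlorophenyl on a shared core

The source may hold more compounds than are shown below. What is called first, only, known or untested is meant among the compounds shown, and "the series" means these compounds.

Compound 1 `COc1cc(-c2ncnn2-c2cccc(N)c2)cc(OC)c1OC` gives > 10000 nM (a limit)
Compound 2 `COc1cc(-n2ncnc2-c2ccc(Cl)c(Cl)c2)cc(OC)c1OC` gives > 10000 nM (a limit)

Both results come from a functional assay on K562 cells (Homo sapiens) for antiproliferative activity, read by MTT assay, with a stated time of 72 h (on this read-out lower numbers stand for stronger inhibition and higher numbers for weaker inhibition), and neither is a true number. Compound 1 reaches only a limit, > 10000 nM (not an exact value). Compound 2 likewise reaches only a limit, > 10000 nM (not an exact value). The whole picture so far is the limit of > 10000 nM in this assay, at which 2 of the 2 values shown sit, and so compound 1 has no exact place on the scale.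

Compound 3 `COc1cc(-c2ncnn2-c2ccc(Cl)cc2)cc(OC)c1OC` keeps the core of compound 1 but carries 4-chlorophenyl in place of 3-aminophenyl on an aromatic nitrogen. Going by the values given here, no measured pair shows what this exchange does. With both measured compounds at the limit, the expectation in this assay is no step beyond the usual scatter and no firm direction, although a measurable value for compound 3 remains possible. The expected change is an at least 1.1-fold lower number from compound 1 to compound 3 (0.04 log units; that floor lies within the scatter) and it rests on very little data. For compound 3 the estimated value is 9000 nM with an expected range from 2000 nM to 30000 nM (an estimate only).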

Compound 3, half-maximal inhibitory concentration: > 10000 nM
Compound 3 gave a limit, no number; the forecaster's own chance of this, stated with the estimate: 60%; at least 1.1-fold (0.04 log units) between middle value and limit.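

Compound 1 and compound 3 both stop at a limit in this assay so no step can be read for 4-chlorophenyl in place of 3-aminophenyl: the limit of > 10000 nM in this assay, at which 3 of the 3 values shown sit.

The compounds shown leave open whether any change on the shared core would give an exact value in this assay and how far from the limit that value would lie.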